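The compounds below may be only part of what the source reports. "The series", "measured", "known", "first", "only" and "open" are said of these compounds alone.

Measured compounds and their values:

Compound 1 `COc1ccc(NC(=O)c2cccc(/C=C3\CC(=O)N(c4ccccc4)C3=O)c2)c(C)c1` gives > 100000 nM.
Compound 2 `Cc1ccc(NC(=O)c2cccc(/C=C3\CC(=O)N(c4ccccc4)C3=O)c2)cc1` gives > 100000 nM.
Compound 3 `CSc1cccc(NC(=O)c2cccc(/C=C3\CC(=O)N(c4ccccc4)C3=O)c2)c1` gives 74300 nM.

In an ADME assay on SW480 cells (Homo sapiens) for cytotoxicity, read by MTT assay, with a stated time of 72 h (on this read-out lower numbers stand for stronger inhibition and higher numbers for weaker inhibition), compound 1 gives > 100000 nM, which is a limit of the assay and not a number. Compound 2 likewise gives > 100000 nM, again a limit. Among the compounds with values here, compound 3 gives 74300 nM, the only number among the three. Compounds 1 and 2 instead sit at the limit of > 100000 nM in this assay, at which 2 of the 3 values shown sit. All three share the same core and differ only in the aryl group on the amide-type nitrogen. The steps to compound 3 are an at least 1.3-fold lower number from compound 1 to compound 3 (0.12 log units; that floor lies within the scatter) and an at least 1.3-fold lower number from compound 2 to compound 3 (0.12 log units; that floor lies within the scatter), both floors within the scatter, while a step that the two limits leave unreadable from compound 1 to compound 2 cannot be read at all.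

Compound 4 `CCc1ccc(NC(=O)c2cccc(/C=C3\CC(=O)N(c4ccccc4)C3=O)c2)cc1` carries the change (4-ethylphenyl in place of 3-(methylsulfanyl)phenyl on an amide-type nitrogen). Within the data shown here, no measured step involves 4-ethylphenyl; the nearest comparison is compound 2 with 4-methylphenyl, which sits at the limit. Every measured exchange of this aryl group has left the number at or near the limit, so compound 4 is expected to sit in this assay at 100000 nM, between 40000 nM and 250000 nM, a step of a 1.3-fold higher number from compound 3 to compound 4 (0.13 log units; within the scatter) that is expected to stay within the scatter, with a fair chance that only a limit is reported.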

Compound 4, half-maximal inhibitory concentration: > 100000 nM
Compound 4: a limit, no number; the forecaster's own chance of this, stated with the estimate: 50%; the middle value lies on the limit itself.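

In this assay compound 4 gives > 100000 nM, which is a limit and not a number. Within the data shown here, the one step that can be read is an at least 1.3-fold higher number from compound 3 to compound 4 (0.12 log units; that floor lies within the scatter), so replacing 3-(methylsulfanyl)phenyl with 4-ethylphenyl on the amide-type nitrogen shows no change beyond the scatter, while the steps joining compound 4 to compound 1 and compound 2 cannot be read. Going from 4-methylphenyl to 4-ethylphenyl therefore yields no number, and compound 3 remains the only compound with one, the others sharing a single ceiling: the limit of > 100000 nM in this assay, at which 3 of the 4 values shown sit.

How far compound 1, compound 2 and compound 4 differ from one another stays hidden behind that limit. On these data alone, it also remains open whether a phenyl group carrying an amine or a carboxylic acid on this nitrogen would give a clearly lower number.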